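Methyl for Chloro on the Aryl Ring of Compound 2

The compounds below may be only part of what the source reports. "The series", "measured", "known", "first", "only" and "open" are said of these compounds alone.

Three compounds of this series have been run in a functional assay on the whole organism for inhibition, with Rattus norvegicus as the target; on this read-out lower numbers stand for an effect already at smaller amounts and higher numbers for an effect only at larger amounts of compound. Compound 1 `CC1C/C(=N\Nc2ccccc2)c2ncc(C(=O)O)c(=O)n2C1` gives 5.7 umol/kg in this assay. Compound 2 `CC1CC/C(=N\Nc2cccc(Cl)c2)c2ncc(C(=O)O)c(=O)n21` gives 0.6 umol/kg, and compound 3 `C[C@@H]1CC/C(=N\Nc2ccc(O)cc2)c2ncc(C(=O)O)c(=O)n21` gives 0.14 umol/kg. Compound 2 thus stands second highest of the three numbers: its value lies beyond the scatter above that of compound 3 and beyond the scatter below that of compound 1, so it sits between the two on this read-out.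

Compound 4 `Cc1cccc(N/N=C2\CCC(C)n3c2ncc(C(=O)O)c3=O)c1` has not yet been measured in this assay. It differs from compound 2 in a single place: methyl in place of chloro on an aromatic carbon. Both groups occupy one heavy atom on the same aromatic carbon, and neither brings or removes a hydrogen-bond donor or acceptor or a charge.

Within the data shown here, with no step between two measured compounds to compare against, the expectation is only that the number of compound 4 lies close to that of compound 2, a step of a 1.3-fold higher number from compound 2 to compound 4 (0.12 log units; within the scatter) that stays within the scatter, with no clear direction. Compound 4 is therefore estimated to give 0.8 umol/kg in this assay, expected to fall between 0.3 umol/kg and 2.5 umol/kg.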

Compound 4, dose for 50% inhibition: 0.4 umol/kg
Compound 4: middle estimate off by 2.0-fold (0.30 log units), on the high side; low and high end bracket the measured number.
By their numbers in this assay, from the lowest: compound 3; then compounds 4 and 2 (each within the scatter of the next); then compound 1.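

This swap gives the series its first step between two compounds that differ in one place: in this assay, replacing chloro with methyl on an aromatic carbon, meta to a large group, gives a 1.5-fold lower number from compound 2 to compound 4 (0.18 log units; within the scatter) and so stays within the scatter. Among these compounds, on this read-out, then, 3-chlorophenyl and 3-methylphenyl cannot be told apart on the shared core, which the earlier compounds, each differing from the others in more than one place, could not show. Nothing available bears on why these two groups read alike.

The compounds shown leave open whether groups of another kind on this same aromatic carbon, such as an amine, a carboxylic acid, methoxy or a longer chain like propyl, would also stay within the scatter of compound 2 or would move the number clearly. As far as these compounds go, it also remains open what any group at this place contributes, since compound 1 carries none there but also has a different core, and whether methyl for chloro would read the same on the other carbons of the ring.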